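This account rests on a few compounds, and the source may have more. Where it says the series, first, only, none or still open, it means among the compounds named here.

Of the compounds shown here, three have so far been measured in a functional assay on COLO 205 cells (Homo sapiens) for antiproliferative activity, read by sulforhodamine B assay, with a stated time of 72 h; a lower number here means a stronger inhibitor, a higher number a weaker inhibitor. Compound 1 `Clc1ccc(C(/C=C/c2ccccc2)=N\Nc2nncc3ccccc23)cc1` gives 5.7 nM, and compound 2 `C(=C/c1ccccc1)\C(=N\Nc1nncc2ccccc12)c1ccccc1` gives 2.4 nM; these two share a core and differ in one place, the step being a 2.4-fold lower number from compound 1 to compound 2 (0.38 log units; beyond the scatter). Compound 3 `Cc1cc(C)nc(NS(=O)(=O)c2ccc(Nc3nncc4ccccc34)cc2)n1` is built on a different frame, and in this assay compound 3 gives 7.9 nM, the highest of the three numbers; its gap to compound 1 lies within the scatter, while its gap to compound 2 lies beyond it. The unmeasured compound 4 `O=S(=O)(Nc1ncccn1)c1ccc(Nc2nncc3ccccc23)cc1` departs from compound 3 by a single change: pyrimidin-2-yl in place of 4,6-dimethylpyrimidin-2-yl on a sulfonamide nitrogen. Within the data shown here, no measured step touches this part of the structure: the only step on record, a 2.4-fold lower number from compound 1 to compound 2 (0.38 log units; beyond the scatter), concerns a different core and a different kind of swap, so it offers no direct guide. Among the measured compounds shown here, with no relevant precedent, the expectation for compound 4 is a step of a 1.3-fold higher number from compound 3 to compound 4 (0.10 log units; within the scatter), which is to say nothing beyond the scatter. Compound 4 is therefore estimated at 10 nM, within a range from 4 nM to 30 nM.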

Compound 4, half-maximal inhibitory concentration: 43 nM
For compound 4 the middle estimate is 4.3-fold (0.63 log units) below the measured one; the whole stated range lies below it.
By their numbers in this assay, from the lowest: compound 2; then compounds 1 and 3 (each within the scatter of the next); then compound 4.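

In this assay, putting pyrimidin-2-yl in place of 4,6-dimethylpyrimidin-2-yl on a sulfonamide nitrogen gives a 5.4-fold higher number from compound 3 to compound 4 (0.74 log units; beyond the scatter), so this part of the structure does respond to change. The ring type and the counted hydrogen-bond donors and acceptors stay the same, which leaves the methyl groups as the only structural difference between the pair. Among these compounds, the one earlier step swapped chloro for hydrogen on a different core, so this is the first measured sign that the sulfonamide substituent matters here.

Nothing shown explains why the number rises with this change. Also open, as far as these compounds go, is whether a single methyl, as in a 4-methylpyrimidin-2-yl group, would recover part of the lost activity, and how an ethyl, methoxy or amino group on the ring would compare.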